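The source may hold more compounds than are shown below. What is called first, only, known or untested is meant among the compounds shown, and "the series" means these compounds.

In a functional assay on HL-60 cells (Homo sapiens) for cytotoxicity, read by WST assay, with a stated time of 48 h (a higher number here means a weaker inhibitor, a lower number a stronger inhibitor), compound 1 (`COc1cc(C(c2ccc(O)c(OC)c2)[C@H](C)C(C)C)ccc1O`) gives 17000 nM and compound 2 (`COc1cc(C(c2ccc(O)c(OC)c2)[C@H](CF)C(C)C)ccc1O`) gives 19000 nM while compound 3 (`COC[C@@H](C(C)C)C(c1ccc(O)c(OC)c1)c1ccc(O)c(OC)c1`) gives 54000 nM as the highest number of the three, which makes it the weakest inhibitor here. Compound 4 (`COc1cc(C(c2ccc(O)c(OC)c2)[C@@H](C)[C@H](C)CO)ccc1O`) has not yet been measured. It changes the group on a saturated chain carbon bound to two aromatic carbons (2-(hydroxymethyl)-1-methylpropyl in place of 1-(methoxymethyl)-2-methylpropyl on a saturated chain carbon bound to two aromatic carbons): 2-(hydroxymethyl)-1-methylpropyl enters and 1-(methoxymethyl)-2-methylpropyl leaves. Among the compounds with values here, no measured compound carries the entering group, so the guidance is indirect. Compound 3 alone carries the leaving group, and it stands apart from the other two by modest steps (a 3.2-fold higher number from compound 1 to compound 3 (0.50 log units; beyond the scatter); a 2.8-fold higher number from compound 2 to compound 3 (0.45 log units; beyond the scatter)). The remaining step (a 1.1-fold higher number from compound 1 to compound 2 (0.05 log units; within the scatter)) lies within the scatter and adds little. Losing that group is therefore expected to bring the number partway back, by a similarly modest amount (a 2.2-fold lower number from compound 3 to compound 4 (0.33 log units; beyond the scatter)). Compound 4 is estimated at 25000 nM (range 9000 nM to 60000 nM).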

Compound 4, half-maximal inhibitory concentration: > 100000 nM
Compound 4: only a limit was reported (the forecaster's own chance of this, stated with the estimate: 10%); middle value at least 4.0-fold (0.60 log units) from the limit.
By their numbers in this assay, from the lowest: compounds 1 and 2 (each within the scatter of the next); then compound 3. At a limit, above all of these: compound 4.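

Compound 4 reaches only a limit in this assay, not a true number: the limit of > 100000 nM in this assay, at which 1 of the 4 values shown sits. Putting 2-(hydroxymethyl)-1-methylpropyl in place of 1-(methoxymethyl)-2-methylpropyl did not bring the number back towards compounds 1 and 2, although the floor of this step (an at least 1.8-fold higher number from compound 3 to compound 4 (0.26 log units; that floor lies within the scatter)) leaves open how far compound 4 truly lies from compound 3. The steps from the two groups without oxygen are clearer (an at least 5.2-fold higher number from compound 2 to compound 4 (0.72 log units; beyond the scatter); an at least 5.8-fold higher number from compound 1 to compound 4 (0.76 log units; beyond the scatter)), and at this place both oxygen-bearing groups shown give higher numbers than those two groups.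

The entering group differs from the leaving one in both its free hydroxyl and its branching, and these compounds do not separate the two changes. As far as these compounds go, how an amine, a carboxylic acid or a longer chain would read here also stays open.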